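The source may report more compounds than this note shows. Statements on the series, on what has been measured and on what is new or still open speak of the compounds shown alone.

Measured in a functional assay on HEp-2 cells (Homo sapiens) for cytotoxicity; a higher number here means a weaker inhibitor, a lower number a stronger inhibitor:
- compound 1 `CS(=O)(=O)c1nc(N)c2nnn(C3O[C@H](CO)[C@@H](O)[C@H]3O)c2n1`: 14000 nM
- compound 2 `CSc1nc(SC)c2nn([C@@H]3O[C@H](COC(C)=O)[C@@H](OC(C)=O)[C@H]3OC(C)=O)nc2n1`: 800 nM
- compound 3 `CS(=O)(=O)c1nc(N)c2nn(C3O[C@H](CO)[C@@H](O)[C@H]3O)nc2n1`: 22000 nM

Compound 3 and compound 1 lie within the scatter of each other at the high end of these numbers, while compound 2 stands beyond the scatter with a lower number. Compound 4 `Nc1nc(O)nc2nn(C3O[C@H](CO)[C@@H](O)[C@H]3O)nc12` differs from compound 3 by hydroxy in place of methylsulfonyl on an aromatic carbon. Among the compounds with values here, no measured pair shows this change, so there is no direct guide to its size. The amino-bearing compound 1 at 14000 nM and compound 3 at 22000 nM are the nearest reference points, so no step beyond the scatter is expected. The expected change is a 1.4-fold higher number from compound 3 to compound 4 (0.13 log units; within the scatter). Compound 4 is estimated at 30000 nM, with an expected range of 10000 nM to 90000 nM.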

Compound 4, half-maximal inhibitory concentration: > 75000 nM
Compound 4 gave a limit, no number; the forecaster's own chance of this, stated with the estimate: 35%; middle value at least 2.5-fold (0.39 log units) from the limit.
By their numbers in this assay, from the lowest: compound 2; then compounds 1 and 3 (each within the scatter of the next). At a limit, above all of these: compound 4.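

Within the data shown here, putting hydroxy in place of methylsulfonyl on this aromatic carbon, between two ring nitrogen atoms, gives an at least 3.4-fold higher number from compound 3 to compound 4 (0.53 log units; beyond the scatter), the first readable step at this position and one beyond the scatter. In this assay compound 4 gives > 75000 nM, which is a limit and not a number. The full size of the step stays unknown because the read-out ends there: the limit of > 75000 nM in this assay, at which 1 of the 4 values shown sits.

A single pair cannot separate the part played by the leaving methylsulfonyl from that of the entering hydroxy. On these data alone, how an amine or a methoxy group on this carbon would read in this assay remains open.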